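The compounds below may be only part of what the source reports. "The series", "measured", "known", "first", "only" and "open" are said of these compounds alone.

Working notes on the series.

Compound 1 `COc1ncnc2c1c(-c1ccsc1)cn2[C@@H]1O[C@H](CO)[C@@H](O)[C@H]1O` carries a methoxy group and a thiophen-3-yl group on the shared core; in a functional assay on CCRF-CEM cells (Homo sapiens), read by MTT assay, with a stated time of 72 h (a higher number here means a weaker inhibitor, a lower number a stronger inhibitor), compound 1 gives 2570 nM. Compound 2 `CNc1ncnc2c1c(-c1ccsc1)cn2[C@@H]1O[C@H](CO)[C@@H](O)[C@H]1O` differs from compound 1 by methylamino in place of methoxy on an aromatic carbon. In this assay compound 2 reaches only > 20000 nM, a limit of the assay and not a number. The step is an at least 7.7-fold higher number from compound 1 to compound 2 (0.89 log units; beyond the scatter), and its size is bounded by the limit of > 20000 nM in this assay, at which 1 of the 3 values shown sits.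

Compound 3 `COc1ncnc2c1c(-c1cc3ccccc3o1)cn2[C@@H]1O[C@H](CO)[C@@H](O)[C@H]1O` differs from compound 1 by 1-benzofuran-2-yl in place of thiophen-3-yl on an aromatic carbon. In this assay compound 3 gives 5370 nM, which is a 2.1-fold higher number from compound 1 to compound 3 (0.32 log units; beyond the scatter). Of the two numbers in hand, compound 3 has the higher one, with compound 1 nearest to it.

Compound 4 `CNc1ncnc2c1c(-c1cc3ccccc3o1)cn2[C@@H]1O[C@H](CO)[C@@H](O)[C@H]1O` has not yet been measured. It differs from compound 3 by methylamino in place of methoxy on an aromatic carbon. The place of the change is described in the same words as for the change from compound 1 to compound 2, so this is the same change made on a second core; the two cores differ only in the exchange already described between compound 1 and compound 3.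

On the earlier occasion the change gave an at least 7.7-fold higher number from compound 1 to compound 2 (0.89 log units; beyond the scatter), ending at a limit. The step expected here is a 7.4-fold higher number from compound 3 to compound 4 (0.87 log units; beyond the scatter), of comparable size, resting on that earlier step. Compound 4 is therefore expected to give about 40000 nM in this assay, with a likely range from 15000 nM to 120000 nM. Compound 3 already gives 5370 nM in this assay. Starting from that number, the expected outcome for compound 4 is most likely a limit rather than a number.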

Compound 4, half-maximal inhibitory concentration: > 20000 nM
Compound 4: only a limit was reported (the forecaster's own chance of this, stated with the estimate: 75%); the middle value does not contradict the limit.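

Replacing methoxy with methylamino on the second core gives an at least 3.7-fold higher number from compound 3 to compound 4 (0.57 log units; beyond the scatter) in this assay, so in both pairs shown the methylamino compound has the higher number, and the direction of the change carries over from the core of compound 1 to the core of compound 3: the same change on two cores in this assay, an at least 7.7-fold higher number (0.89 log units; beyond the scatter) from compound 1 to compound 2 and an at least 3.7-fold higher number (0.57 log units; beyond the scatter) from compound 3 to compound 4; the limit leaves it open whether they differ

This shows agreement in direction for these two pairs only, and it gives no general rule for the series or for any other core. It does not show that the size of the step carries over, and the step between compound 2 and compound 4 cannot be read, since both methylamino compounds stop at the same limit of the assay: the limit of > 20000 nM in this assay, at which 2 of the 4 values shown sit.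

The compounds shown leave open how much weaker compound 2 and compound 4 really are, and whether the benzofuran-2-yl and thiophen-3-yl groups still separate once methylamino is present. They also leave open whether the steep rise in the number belongs to methylamino alone or would also follow from an unsubstituted amino group, a dimethylamino group or an ethoxy group in the same place on either core.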